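Guanidine series: ring substituent at the double-bonded nitrogen

The compounds below may be only part of what the source reports. "The series", "measured", "known", "first", "only" and "open" are said of these compounds alone.

Measured so far:
Compound 1 `N#CNC(=N)Nc1cccnc1` — 50 mg/kg
Compound 2 `CCC/N=C(\NC#N)Nc1cccnc1` — 20 mg/kg
Compound 3 `CCC(CC)(CC)/N=C(\NC#N)Nc1cccnc1` — 1 mg/kg

All three share one core and differ only in the group carried on the double-bonded nitrogen. In a functional assay on the whole organism (blood, strain Wistar-Okamoto) with Rattus norvegicus as the target, with a stated time of 5 days (a lower number here means that less compound is needed, a higher number that more compound is needed for the effect), compound 2, with its propyl group, gives 20 mg/kg and stands second highest of the three numbers: compound 1 gives 50 mg/kg, a higher number and beyond the scatter, while compound 3 gives 1 mg/kg, a lower number and also beyond the scatter. No two of these compounds differ in a single counted step, so only the values themselves can be compared.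

Compound 4 `CC1(/N=C(\NC#N)Nc2cccnc2)CCC1` is not yet measured. It differs from compound 2 in one place: 1-methylcyclobutyl in place of propyl on a double-bonded nitrogen. The step from compound 2 to compound 4 is expected to lower the number beyond the scatter, by about a 6.7-fold lower number from compound 2 to compound 4 (0.82 log units; beyond the scatter), because compound 3, which also carries a branched group on that nitrogen, gives 1 mg/kg. For compound 4 the minimum effective dose in this assay is estimated at 3 mg/kg, within 1 mg/kg to 10 mg/kg.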

Compound 4, minimum effective dose: 50 mg/kg
For compound 4 the middle estimate is 17-fold (1.22 log units) below the measured one; the measured number lies above the stated range.
By their numbers in this assay, from the lowest: compound 3; then compound 2; then compounds 1 and 4 (each within the scatter of the next).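

In this assay, 1-methylcyclobutyl in place of propyl on the double-bonded nitrogen gives a 2.5-fold higher number from compound 2 to compound 4 (0.40 log units; beyond the scatter), so a branched group at this position does not by itself lower the number. Compound 3, also branched there, gives 1 mg/kg, while compound 4 gives 50 mg/kg, level with compound 1 at 50 mg/kg, so the two branched groups lie far apart and the outcome depends on which branched group is present. Nothing available bears on the reason for this result.

On these data alone, it remains open whether an open-chain group such as 1,1-dimethylpropyl would read like compound 3 or like compound 4. Also open, as far as these compounds go, is how a larger ring, such as 1-methylcyclopentyl or 1-methylcyclohexyl, would read at this position.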